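From methyl to chloro on an aromatic carbon

The compounds below may be only part of what the source reports. "The series", "measured", "known", "first", "only" and "open" are said of these compounds alone.

Values so far in a functional assay on liver (Rattus norvegicus, strain Sprague-Dawley) for inhibition, with a stated time of 1 h; on this read-out higher numbers stand for weaker inhibition and lower numbers for stronger inhibition:
- compound 1 `CCOC(=O)CC(=O)OCC1Oc2ccc([C@H]3Oc4cc(O)cc(O)c4C(=O)[C@@H]3O)cc2OC1c1ccc(O)c(OC)c1`: 33400 nM
- compound 2 `COc1cc(C2Oc3cc([C@H]4Oc5cc(O)cc(O)c5C(=O)[C@@H]4O)ccc3OC2COC(=O)/C=C/c2ccc(C)cc2)ccc1O`: 14700 nM

Compound 2 has the lower of these two numbers, which means the stronger inhibition. Compound 3 `COc1cc(C2Oc3cc([C@H]4Oc5cc(O)cc(O)c5C(=O)[C@@H]4O)ccc3OC2COC(=O)/C=C/c2ccc(Cl)cc2)ccc1O` differs from it by chloro in place of methyl on an aromatic carbon, para to a large group (chloro in place of methyl on an aromatic carbon). Going by the values given here, the only measured step, a 2.3-fold lower number from compound 1 to compound 2 (0.36 log units; beyond the scatter), exchanged a whole side group. This smaller change is therefore expected to move the number in this assay no further, probably not beyond the scatter, and in no known direction. The expected step is a 1.1-fold lower number from compound 2 to compound 3 (0.02 log units; within the scatter). The estimate for compound 3 is 14000 nM, with an expected range from 7000 nM to 29000 nM.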

Compound 3, half-maximal inhibitory concentration: 12000 nM
For compound 3 the middle estimate is 1.2-fold (0.07 log units) above the measured one, within the range that was stated.
By their numbers in this assay, from the lowest: compounds 3 and 2 (each within the scatter of the next); then compound 1.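

Within this assay, chloro and methyl on this aromatic carbon cannot be told apart (a 1.2-fold lower number from compound 2 to compound 3 (0.09 log units; within the scatter)), so this position accepts either group with no readable difference. The advantage of the arylethenyl side group over (ethoxycarbonyl)methyl holds with chloro in place as well (a 2.8-fold lower number from compound 1 to compound 3 (0.44 log units; beyond the scatter)). Nothing available here explains either step.

Still open, on these data alone, is whether a larger or different group on this carbon, such as methoxy, an amine or a carboxylic acid, would separate from these two. Also open, as far as these compounds go, is how a plain phenyl ring without any such group would compare.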